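Three Analogues at the Cytotoxicity Limit and a Fourth

This account rests on a few compounds, and the source may have more. Where it says the series, first, only, none or still open, it means among the compounds named here.

Measured so far in an ADME assay on Huh-7 cells (Homo sapiens) for cytotoxicity; on this read-out lower numbers stand for higher toxicity in this test and higher numbers for lower toxicity in this test:
compound 1, `Cc1ccccc1-c1nn(-c2ccccc2Cl)cc1CNCCN1CCN(C)CC1`, gives > 20000 nM, a limit of the assay.
compound 2, `Cc1ccccc1-c1nn(-c2cc(F)ccc2F)cc1CNCCN1CCN(C)CC1`, gives > 20000 nM, also a limit.
compound 3, `Cc1ccccc1-c1nn(-c2ccc(F)c(F)c2)cc1CNCCN1CCN(C)CC1`, gives > 20000 nM, again a limit.

Compound 3 thus stands where the other two stand, at the limit of > 20000 nM in this assay, at which 3 of the 3 values shown sit. The steps a step that the two limits leave unreadable from compound 1 to compound 2, a step that the two limits leave unreadable from compound 1 to compound 3 and a step that the two limits leave unreadable from compound 2 to compound 3 are all unreadable: each joins two limits. Compound 4, `Cc1ccccc1-c1nn(-c2ccc(F)cc2)cc1CNCCN1CCN(C)CC1`, differs from compound 3 by hydrogen in place of fluoro on an aromatic carbon, ortho to a fluoro group and meta to a large group. Among the compounds with values here, no measured step gives a readable size for such a change; all three sit at the limit of > 20000 nM in this assay, at which 3 of the 3 values shown sit. Compound 4 is therefore expected to stay at the limit, a step that the limit leaves unreadable from compound 3 to compound 4 of no readable size. The value of compound 4 in this assay is estimated at 30000 nM, within 15000 nM to 80000 nM.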

Compound 4, half-maximal cytotoxic concentration: > 20000 nM
Compound 4 was reported as a limit; the forecaster's own chance of this, stated with the estimate: 85%; the middle value is on the limit's open side.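

No step between compound 1, compound 2, compound 3 and compound 4 can be read, because all four sit at a limit: the limit of > 20000 nM in this assay, at which 4 of the 4 values shown sit.

The compounds shown leave open where each true value lies beyond that limit, and whether these substituent changes shift the read-out at all.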